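The source may report more compounds than this note shows. Statements on the series, on what has been measured and on what is new or still open speak of the compounds shown alone.

Three compounds have been measured in an assay on HEK293 cells for agonist activity at Bile acid receptor (Homo sapiens); on this read-out higher numbers stand for larger maximal responses and lower numbers for smaller maximal responses:

Compound 1 `O=C(O)c1cccc(C2CC2c2ccc(OCc3c(-c4c(Cl)cccc4Cl)noc3C3CC3)cc2Cl)c1` gives 87% in this assay.
Compound 2 `CC(C)n1nc(C(=O)O)cc1C1CC1c1ccc(OCc2c(-c3c(Cl)cccc3Cl)noc2C2CC2)cc1Cl` gives 81% in this assay.
Compound 3 `CC(C)n1nc(C(=O)O)cc1[C@@H]1C[C@H]1c1ccc(OCc2c(-c3c(Cl)cccc3Cl)noc2C2CC2)cc1Cl` gives 79% in this assay.

All three share the same large framework and differ only at one saturated ring carbon of the three-membered ring. Compound 2 and compound 3 have the same atoms and bonds; they differ in how the ring is drawn, (the two compounds have the same atoms and bonds; at least one stereo element is drawn with a configuration in one of them and without one in the other: 2 of 2 stereo elements differ; a stereocentre at a saturated ring carbon is drawn without a configuration in compound 2 and R in compound 3; a stereocentre at a saturated ring carbon is drawn without a configuration in compound 2 and R in compound 3), and this drawing is the only thing that sets them apart (the fact that one of compounds 2 and 3 is drawn with a defined configuration and the other without, at the place where they differ). Their values sit close together, a number 2 percentage points lower from compound 2 to compound 3 (within the scatter).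

Between compound 2 and compound 1 the group on that ring carbon is exchanged, (3-carboxyphenyl in place of 3-carboxy-1-isopropyl-1H-pyrazol-5-yl on a saturated ring carbon). The measured outcome of that exchange is small, a number 6 percentage points higher from compound 2 to compound 1 (within the scatter).

Compound 4 `O=C(O)c1cccc([C@@H]2C[C@H]2c2ccc(OCc3c(-c4c(Cl)cccc4Cl)noc3C3CC3)cc2Cl)c1` has not yet been measured. It stands to compound 3 as compound 1 stands to compound 2: the same exchange at the same place, (3-carboxyphenyl in place of 3-carboxy-1-isopropyl-1H-pyrazol-5-yl on a saturated ring carbon). The "place" around the exchanged group is described in the same words for both pairs, so the change is the same one, made on the drawn form of the core rather than on the undrawn one.

Going by the values given here, with only one earlier example of this exchange to lean on, and that example within the scatter, the step expected from compound 3 to compound 4 in this assay is about as small as the step seen between compound 2 and compound 1, a number 6 percentage points higher from compound 2 to compound 1 (within the scatter), so the expected step is a number 6 percentage points higher from compound 3 to compound 4 (within the scatter). Compound 4 is therefore estimated to reach 85% in this assay, with the expectation spanning from 72% to 98%.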

Compound 4, largest response reached (reported as efficacy), in percent of the reference or control that the assay uses: 98%
Estimate against measurement, compound 4: 13 percentage points below; the range from low to high includes it.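

In this assay, putting 3-carboxyphenyl in place of 3-carboxy-1-isopropyl-1H-pyrazol-5-yl on the core with a drawn configuration gives a number 19 percentage points higher from compound 3 to compound 4 (beyond the scatter). Set beside the same exchange on the core drawn without a configuration, this step cannot be told apart from the earlier one: the same change on two cores in this assay, a number 6 percentage points higher (within the scatter) from compound 2 to compound 1 and a number 19 percentage points higher (beyond the scatter) from compound 3 to compound 4, 13 percentage points apart, within the scatter of two such steps. The pairs therefore give no sign that the exchange behaves differently on the two drawn forms, but with one pair on each they do not show that its size carries over reliably, and they say nothing about any other core.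

The comparison of the two forms that carry 3-carboxyphenyl gives a number 11 percentage points higher from compound 1 to compound 4 (beyond the scatter), yet it leaves open what the other possible configurations of the three-membered ring would give on their own, as the only difference recorded is a configuration drawn in one compound and left undrawn in the other: the fact that one of compounds 1 and 4 is drawn with a defined configuration and the other without, at the place where they differ. Also open, as far as these compounds go, is whether a tetrazole or a primary amide in place of the carboxylic acid on the 3-carboxyphenyl group would keep a response of this size in this assay.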